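Phenyl on the hydrazone nitrogen: a step from compound 1

The compounds below may be only part of what the source reports. "The series", "measured", "known", "first", "only" and "open" are said of these compounds alone.

Compound 1 `N/N=C/c1cc2ccccc2[nH]c1=O` is measured in a functional assay, read by spectrophotometry, with a stated time of 3 min (on this read-out higher numbers stand for weaker inhibition and lower numbers for stronger inhibition), where compound 1 gives 20600 nM. Among the three measured compounds it holds the second highest number. Compound 2 `Cc1ccc2[nH]c(=O)c(/C=N/N)cc2c1` gives 11300 nM, and the step of a 1.8-fold lower number from compound 1 to compound 2 (0.26 log units; within the scatter) is a methyl in place of hydrogen on an aromatic carbon. Compound 3 `CCCC/N=C/c1cc2ccccc2[nH]c1=O` gives 1810000 nM, and the step of an 88-fold higher number from compound 1 to compound 3 (1.94 log units; beyond the scatter) is a butyl in place of amino on a double-bonded nitrogen.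

Compound 4 `O=c1[nH]c2ccccc2cc1/C=N/Nc1ccccc1` has not yet been measured. It differs from compound 1 in one place: phenyl in place of hydrogen on an amine nitrogen. Within the data shown here, the only measured step that bears on this change is the one from compound 1 to compound 3, where altering the group on the double-bonded nitrogen sharply raised the number. Compound 4 keeps the amine nitrogen but carries a phenyl on it, so a weakening is expected, though smaller than in that step. Compound 4 is therefore expected to give 100000 nM in this assay, between 20000 nM and 500000 nM, a step of a 4.9-fold higher number from compound 1 to compound 4 (0.69 log units; beyond the scatter).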

Compound 4, half-maximal inhibitory concentration: 11800 nM
The estimate for compound 4 lay 8.5-fold (0.93 log units) above the measured number, and the stated range ends above it.
By their numbers in this assay, from the lowest: compounds 2, 4 and 1 (each within the scatter of the next); then compound 3.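

In this assay, phenyl in place of hydrogen on an amine nitrogen gives a 1.7-fold lower number from compound 1 to compound 4 (0.24 log units; within the scatter), so this nitrogen carries an aromatic ring of carbon with no change beyond the scatter. The earlier compounds shown here showed only an 88-fold higher number from compound 1 to compound 3 (1.94 log units; beyond the scatter), where butyl replaces the amino group, and compound 4 now shows that a substituent on this part of compound 1 does not by itself bring a rise of that size, at least when the amine nitrogen stays in place. No measured evidence here explains why phenyl is accepted at this nitrogen.

Going by these compounds, whether butyl on the amine nitrogen would follow phenyl or the large rise seen with compound 3 remains open. So does the outcome for a pyridyl ring or an acetyl group at this nitrogen, or for phenyl combined with the methyl on the aromatic carbon of compound 2.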